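Swapping Bromine for a Nitrile on the Outer Ring

The compounds below may be only part of what the source reports. "The series", "measured", "known", "first", "only" and "open" are said of these compounds alone.

Measured compounds:
Compound 1 `Fc1ccc(F)c(-c2nc3ncccc3o2)c1` gives 18%.
Compound 2 `N#Cc1cccc(F)c1-c1nc2ncccc2o1` gives 50%.
Compound 3 `Brc1cccc(-c2nc3ncccc3o2)c1` gives 23%.

All three share the same core and differ only in the groups attached to the six-membered carbon ring at one end. They were tested in a functional assay on the whole organism for inhibition, with Rattus norvegicus as the target, at a dose of 30 mg/kg; a higher number here means more inhibition at the dose given (going by the name of the read-out), a lower number less inhibition. Compound 3 stands well below compound 2, whose value is beyond the usual scatter of this measurement, and close to compound 1, whose value lies within that scatter of compound 3, so no order between compound 3 and compound 1 can be read from these numbers.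

The next compound to consider is compound 4 `N#Cc1cccc(-c2nc3ncccc3o2)c1`. Compared with compound 3, the change is cyano in place of bromo on an aromatic carbon. The new group is placed on an aromatic carbon of a six-membered aromatic ring of carbon only, meta to a group of 9 heavy atoms. For the measured compounds named here, no step between two already measured compounds matches this change exactly, so the size of its effect is uncertain.

For compound 4 the expected step is a number 12 percentage points higher from compound 3 to compound 4 (beyond the scatter), an increase of moderate size, because compound 2, which also carries a cyano group, gives 50%. Compound 4 is therefore estimated at 35%, with a likely range from 15% to 55%.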

Compound 4, a percentage reported as inhibition, in the whole organism at one dose (the size of the read-out at that dose, not a potency): 21%
The estimate for compound 4 lay 14 percentage points above the measured number; the range from low to high includes it.
By their numbers in this assay, from the lowest: compounds 1, 4 and 3 (each within the scatter of the next); then compound 2.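

In this assay, putting cyano in place of bromo on the aromatic carbon, meta to a group of 9 heavy atoms, gives a number 2 percentage points lower from compound 3 to compound 4 (within the scatter), so at this position the two groups cannot be told apart by this read-out. For the compounds shown here, this is the first pair in the set that differs in only one place, and it shows that the change from one heavy atom to two, with one hydrogen-bond acceptor added, leaves the number within the usual scatter. Nothing measured here explains why the two groups read alike.

Going by these compounds alone, no pair differing in one place connects compound 2, at 50%, with the other compounds, so the source of its value remains open, including what part its fluoro group and the different position of its cyano group may play. Also open, on these data alone, is whether a clearly different group on the same aromatic carbon, such as an amine or a carboxylic acid, would move the number beyond the scatter of compound 3 and compound 4.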